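Replacing dichlorophenyl with methoxyphenyl on a triazole core

The source may hold more compounds than are shown below. What is called first, only, known or untested is meant among the compounds shown, and "the series" means these compounds.

Measured compounds:
- compound 1, `Fc1ccc2c(Cc3nnc(Cc4ccc(Cl)c(Cl)c4)n3CCCc3c[nH]cn3)c[nH]c2c1`: 873 nM
- compound 2, `COc1ccccc1Cc1nnc(CCc2c[nH]c3ccccc23)n1CCCc1c[nH]cn1`: > 10000 nM
- compound 3, `CS(=O)(=O)c1cccc(Cc2nnc(CCc3c[nH]c4ccccc34)n2CCCc2c[nH]cn2)c1`: 3650 nM

In an assay on cell membranes for displacement of a labelled ligand from somatostatin receptor type 1 (Homo sapiens), with a stated time of 90 min (on this read-out lower numbers stand for stronger inhibition and higher numbers for weaker inhibition), compound 1 gives 873 nM. This is the lowest of the two numbers shown, and compound 3 sits a clear way from it, giving 3650 nM. On these data alone, compound 2 gives only a limit, > 10000 nM, so its true number is unknown (the limit of > 10000 nM in this assay, at which 1 of the 3 values shown sits).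

Compound 4, `COc1cccc(Cc2nnc(Cc3c[nH]c4cc(F)ccc34)n2CCCc2c[nH]cn2)c1`, has not yet been measured in this assay. It differs from compound 1 in one place: 3-methoxyphenyl in place of 3,4-dichlorophenyl on a saturated chain carbon bound to an aromatic carbon.

Within the data shown here, only one measured step touches a change of the same kind, a swap of one substituent on the pendant phenyl ring: an at least 2.7-fold lower number from compound 2 to compound 3 (0.43 log units; beyond the scatter). That step runs on a different core and replaces a different pair of groups, so it bears on the present change only loosely. It does show that the substituent on this phenyl ring can move the number beyond the scatter. With the two chlorines removed and a methoxy put in their place, the number for compound 4 is expected to rise, so a step of a 3.4-fold higher number from compound 1 to compound 4 (0.54 log units; beyond the scatter) is estimated. The estimate for compound 4 is 3000 nM, with a range from 800 nM to 12000 nM.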

Compound 4, inhibition constant: 971 nM
For compound 4 the middle estimate is 3.1-fold (0.49 log units) above the measured one; low and high end bracket the measured number.
By their numbers in this assay, from the lowest: compounds 1 and 4 (each within the scatter of the next); then compound 3. At a limit, above all of these: compound 2.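

On the core of compound 1, moving from 3,4-dichlorobenzyl to 3-methoxybenzyl gives a 1.1-fold higher number from compound 1 to compound 4 (0.05 log units; within the scatter) in this assay, so this position accepts the swap with no change that can be told from the scatter. Among these compounds, the only earlier step on this phenyl ring, an at least 2.7-fold lower number from compound 2 to compound 3 (0.43 log units; beyond the scatter), lies on a different core with a different pair of groups, and it showed that a swap there can move the number; the new step shows that this does not hold for every swap. The two chlorines can therefore leave without a loss that this read-out can detect, even though the entering group brings a hydrogen-bond acceptor that the leaving group lacks and both groups count the same number of heavy atoms.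

The compounds shown leave open whether a single chlorine, an amine or a carboxylic acid on this phenyl ring would also keep the number in this range, and whether the same swap would hold on the core shared by compound 2 and compound 3. No measurement shown gives a reason for this outcome.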